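The compounds below may be only part of what the source reports. "The series", "measured", "known", "first", "only" and "open" are said of these compounds alone.

Measured compounds in an assay on LtK cells with ATP-sensitive inward rectifier potassium channel 11 (Homo sapiens) as the target; on this read-out higher numbers stand for an effect only at larger amounts of compound and lower numbers for an effect already at smaller amounts:
compound 1 `CC(C)C(=O)Nc1c(C(O)(C(F)(F)F)C(F)(F)F)ccc2ccccc12` — 6630 nM
compound 2 `CCC(C)C(=O)Nc1c(C(O)(C(F)(F)F)C(F)(F)F)ccc2ccccc12` — 177000 nM
compound 3 `C/C=C/C(=O)Nc1c(C(O)(C(F)(F)F)C(F)(F)F)ccc2ccccc12` — 72 nM

Compound 3 holds the lowest number of the three in this assay: the steps of a 92-fold lower number from compound 1 to compound 3 (1.96 log units; beyond the scatter) and a 2500-fold lower number from compound 2 to compound 3 (3.39 log units; beyond the scatter) both lie well beyond the scatter. Compound 4 `CC(C)CCC(=O)Nc1c(C(O)(C(F)(F)F)C(F)(F)F)ccc2ccccc12` has not yet been measured; it differs from compound 3 in one place: isopentyl in place of prop-1-en-1-yl on a carbonyl carbon.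

For the measured compounds named here, two measured steps bear on this change. The step of a 92-fold lower number from compound 1 to compound 3 (1.96 log units; beyond the scatter) shows that exchanging a saturated group on the carbonyl carbon for prop-1-en-1-yl lowered the number sharply, so the reverse direction, back to a saturated chain, should raise it. The step of a 27-fold higher number from compound 1 to compound 2 (1.43 log units; beyond the scatter) shows that a larger saturated chain raised the number further still. Compound 4 carries a saturated chain of five carbon atoms, larger than either isopropyl or sec-butyl, though without the branching at the chain carbon next in line to the carbonyl that compound 2 has. A large rise in this assay is therefore expected, probably of a size between those two steps combined and the first alone: the expected step is a 280-fold higher number from compound 3 to compound 4 (2.44 log units; beyond the scatter). For compound 4 the estimate in this assay is 20000 nM, with a range from 3000 nM to 150000 nM.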

Compound 4, half-maximal effective concentration: 49 nM
For compound 4 the middle estimate is 410-fold (2.61 log units) above the measured one, outside the stated range (below it).
By their numbers in this assay, from the lowest: compounds 4 and 3 (each within the scatter of the next); then compound 1; then compound 2.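

In this assay, the step of a 1.5-fold lower number from compound 3 to compound 4 (0.17 log units; within the scatter) shows that a double bond in the group on this carbonyl carbon is not needed for a low number, since the saturated isopentyl group and prop-1-en-1-yl cannot be told apart here. Saturated groups at this place also differ widely among themselves, as the steps of a 140-fold lower number from compound 1 to compound 4 (2.13 log units; beyond the scatter) and a 3600-fold lower number from compound 2 to compound 4 (3.56 log units; beyond the scatter) show, so the rise seen on going from isopropyl to sec-butyl is no general rule that larger saturated groups raise the number, and compound 4 goes against that reading. Nothing shown here explains these differences.

Still open, from the compounds shown here alone, is whether the shape of the saturated group or its length decides the outcome, a question that a straight propyl or pentyl chain on the same carbonyl carbon would help to settle. Also open, going by these compounds, is how far this tolerance extends, for instance to a longer chain or to a chain ending in a carboxylic acid or an amine.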